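The source may report more compounds than this note shows. Statements on the series, on what has been measured and on what is new or still open speak of the compounds shown alone.

Measured compounds:
- compound 1 `O=C(OC1(C(=O)Nc2ccc([N+](=O)[O-])cc2)CCCCC1)c1ccc(Br)cc1` — 523 nM in an ADME assay on WI-38 cells (Homo sapiens) for inhibition, read by MTT assay, with a stated time of 72 h; a lower number here means a stronger inhibitor, a higher number a weaker inhibitor
- compound 2 `CCOC(=O)c1ccccc1C(=O)OC1(C(=O)Nc2ccc([N+](=O)[O-])cc2)CCCCC1` — 386 nM in this assay

Two compounds share a core built from a cyclohexane carbon bearing an anilide of a nitro-substituted aniline and an ester on the same carbon. In this assay compound 1 gives 523 nM, and in this assay compound 2 gives 386 nM. The gap between them is within the usual scatter of the method, so compound 1 is not separated from compound 2 on these numbers; neither one can be called the stronger or the weaker inhibitor.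

Compound 3 `O=COC1(C(=O)Nc2ccc([N+](=O)[O-])cc2)CCCCC1` has not been measured. It differs from compound 1 in one place: hydrogen in place of 4-bromophenyl on a carbonyl carbon. The ester is thereby cut back from a (4-bromophenyl)carbonyl to a formyl group. Among the compounds with values here, no step between measured compounds speaks to this change, and the pair of compound 1 and compound 2 only shows that swapping one aryl ester for another left the number within the scatter.

Given the loss of the whole aromatic ring, compound 3 is expected to be a weaker inhibitor than compound 1, with an estimated step of a 2.9-fold higher number from compound 1 to compound 3 (0.46 log units; beyond the scatter). Compound 3 is estimated at 1500 nM, in a range from 400 nM to 6000 nM.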

Compound 3, half-maximal inhibitory concentration: 46.3 nM
Estimate against measurement, compound 3: 32-fold (1.51 log units) above; the measured number lies below the stated range.
By their numbers in this assay, from the lowest: compound 3; then compounds 2 and 1 (each within the scatter of the next).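

In this assay the carbonyl carbon of the ester proves to be a place where the substituent can move the number a long way: hydrogen in place of 4-bromophenyl gives an 11-fold lower number from compound 1 to compound 3 (1.05 log units; beyond the scatter) and turns the (4-bromophenyl)carbonyl into a formyl group. The pair of compound 1 and compound 2 had shown only two aromatic esters whose numbers lie within the scatter of each other, whereas compound 3 shows that an aromatic ring on this carbonyl carbon is not required for a low number and that the compound lacking it is the stronger inhibitor of the pair. Nothing among the data shown accounts for the size or the direction of this step.

The compounds shown leave open whether the low number is particular to the formyl group or would persist with a methyl group, a longer chain or an amine on this carbonyl carbon. They also leave open whether a plain phenyl, without the bromine, would stand with compound 1 or closer to compound 3.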